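The source may report more compounds than this note shows. Statements on the series, on what has been measured and on what is new or still open speak of the compounds shown alone.

Measured compounds in a functional assay on U2OS cells (Homo sapiens) for antiproliferative activity, read by MTT assay, with a stated time of 72 h; on this read-out lower numbers stand for stronger inhibition and higher numbers for weaker inhibition:
- compound 1 `O=C(CSc1cccc(O)c1)Nc1ccc2nc(NC(=O)c3ccc(C(F)(F)F)cc3)sc2c1` gives 630 nM
- compound 2 `O=C(CSc1cccc(O)c1)Nc1ccc2nc(NC(=O)c3cccs3)sc2c1` gives 63000 nM
- compound 3 `O=C(CSc1cccc(O)c1)Nc1ccc2nc(NC(=O)c3ccccc3)sc2c1` gives > 100000 nM

Compound 3 stands at the weak end of what has been measured. For compound 3 the value > 100000 nM is a limit of the assay, not a number, the same limit as the limit of > 100000 nM in this assay, at which 1 of the 3 values shown sits, describes. Among the compounds with values here, the one step within the measured set that reaches compound 3 is an at least 150-fold higher number from compound 1 to compound 3 (2.20 log units; beyond the scatter), and the step of an at least 1.5-fold higher number from compound 2 to compound 3 (0.20 log units; that floor lies within the scatter) adds little, as its floor sits in the scatter.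

Compound 4 `Cc1ccc(C(=O)Nc2nc3ccc(NC(=O)CSc4cccc(O)c4)cc3s2)cc1` is not yet measured. Compared with compound 3 the change is methyl in place of hydrogen on an aromatic carbon. The measured steps that bear on it are those touching the same aromatic carbon: an at least 150-fold higher number from compound 1 to compound 3 (2.20 log units; beyond the scatter) shows that a trifluoromethyl at that position, in place of hydrogen, goes with a much lower number. A methyl is a different group, so that step is only a loose guide, and the comparison of compound 2 with compound 3 shows that a change of the acyl ring on its own does not move the number far. Some lowering of the number from compound 3 to compound 4 is expected, but smaller than an at least 150-fold higher number from compound 1 to compound 3 (2.20 log units; beyond the scatter) reversed; the step of an at least 3.3-fold lower number from compound 3 to compound 4 (0.52 log units; beyond the scatter) is the estimate. Compound 4 is therefore expected at about 30000 nM, within a range from 5000 nM to 150000 nM.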

Compound 4, half-maximal inhibitory concentration: 12400 nM
Beside the measured number, compound 4's estimate is 2.4-fold (0.38 log units) above it; low and high end bracket the measured number.
By their numbers in this assay, from the lowest: compound 1; then compound 4; then compound 2. At a limit, above all of these: compound 3.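

In this assay, the position para to a large group on the acyl ring now has a reading for a single added carbon, and methyl in place of hydrogen is enough to bring a measurable number: an at least 8.0-fold lower number from compound 3 to compound 4 (0.90 log units; beyond the scatter). The value of compound 3 is a limit of the assay and not a number, which makes that step a floor only: the limit of > 100000 nM in this assay, at which 1 of the 4 values shown sits. The group's identity counts as well as its presence, since methyl does not match trifluoromethyl, with a 20-fold higher number from compound 1 to compound 4 (1.29 log units; beyond the scatter), while the 4-methylphenyl carbonyl still reads lower than the thiophen-2-yl carbonyl, with a 5.1-fold lower number from compound 2 to compound 4 (0.71 log units; beyond the scatter).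

The compounds shown carry only hydrogen, methyl and trifluoromethyl at this position, and they leave open how an ethyl, a chlorine, a methoxy, an amine or a carboxylic acid there would read. They also leave open whether the same order holds when the hydroxyl on the sulfur-linked phenyl ring is moved or replaced, as that part stays the same in all four compounds.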